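Benzimidazole series: benzothiazolylmethyl to chlorobenzothiophenylmethyl on the ring nitrogen

This account rests on a few compounds, and the source may have more. Where it says the series, first, only, none or still open, it means among the compounds named here.

Compound 1 `NC(=O)c1ccc2c(c1)nc(Nc1ccc(S(N)(=O)=O)cc1)n2C1(c2ccccc2)CC1` in an assay on isolated protein for inhibition of kinesin heavy chain isoform 5A (Homo sapiens) (a lower number here means a stronger inhibitor, a higher number a weaker inhibitor), returns only the limit > 50000 nM.
Compound 2 `NC(=O)c1ccc2c(c1)nc(Nc1ccc(S(N)(=O)=O)cc1)n2Cc1ccccn1` in this assay returns only the limit > 50000 nM.
Compound 3 `NC(=O)c1ccc2c(c1)nc(Nc1ccc(S(N)(=O)=O)cc1)n2Cc1nc2ccccc2s1` in this assay returns only the limit > 50000 nM.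

Compound 3 thus stands at the limit of this assay, where all three measured compounds sit (the limit of > 50000 nM in this assay, at which 3 of the 3 values shown sit); no number separates it from compound 1 or compound 2. The steps between the measured compounds are accordingly unreadable: a step that the two limits leave unreadable from compound 1 to compound 2, a step that the two limits leave unreadable from compound 1 to compound 3 and a step that the two limits leave unreadable from compound 2 to compound 3 all run between two limits and give no size.

Compound 4 `NC(=O)c1ccc2c(c1)nc(Nc1ccc(S(N)(=O)=O)cc1)n2Cc1csc2ccc(Cl)cc12` differs from compound 3 in one place: 5-chloro-1-benzothiophen-3-yl in place of 1,3-benzothiazol-2-yl on a saturated chain carbon bound to an aromatic nitrogen. For the measured compounds named here, the measured steps that bear on this change, the three substituent swaps at the same aromatic nitrogen, were all unreadable, so they give no direction and no size for the step in this assay. Going by the values given here, the only evidence is that every variation at this position so far stays at the limit (the limit of > 50000 nM in this assay, at which 3 of the 3 values shown sit). The step from compound 3 to compound 4 is therefore expected to be a step that the limit leaves unreadable from compound 3 to compound 4, that is, none that can be read. For compound 4 the estimated value in this assay is 60000 nM, with an expected range from 15000 nM to 300000 nM, most likely reported again only as a limit.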

Compound 4, half-maximal inhibitory concentration: > 50000 nM
Compound 4: only a limit was reported; the forecaster's own chance of this, stated with the estimate: 85%; the middle value does not contradict the limit.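

Compound 4 also returns only a limit in this assay, so its steps to compound 1, compound 2 and compound 3 cannot be read: the limit of > 50000 nM in this assay, at which 4 of the 4 values shown sit.

The compounds shown leave open whether any group on this aromatic nitrogen gives a measurable value in this assay, and how large any step would be.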